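The source may hold more compounds than are shown below. What is called first, only, known or untested is meant among the compounds shown, and "the series" means these compounds.

Measured so far in an assay on BaF3 cells with thrombopoietin receptor (Homo sapiens) as the target, read by a luciferase reporter; on this read-out lower numbers stand for smaller maximal responses and higher numbers for larger maximal responses:
compound 1, `O=[N+]([O-])c1cc(O)c(/N=N/c2c(O)ccc3ccccc23)c2ccccc12`, gives < 5%, a limit of the assay.
compound 2, `O=S(=O)(O)c1cc(O)c(/N=C/c2c(O)ccc3ccccc23)c2ccccc12`, gives < 5%, also a limit.
compound 3, `Cc1[nH]n(C(C)(C)C)c(=O)c1/N=N/c1c(O)cc(S(=O)(=O)O)c2ccccc12`, gives < 5%, again a limit.

Compound 3 thus sits at the floor of this assay, and no number is known for it; the limit of < 5% in this assay, at which 3 of the 3 values shown sit, covers all three values shown, so nothing among them separates compound 3 from the others.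

Compound 4, `Cc1ccc(-n2[nH]c(C)c(/N=N/c3c(O)cc(S(=O)(=O)O)c4ccccc34)c2=O)cc1C`, differs from compound 3 only by 3,4-dimethylphenyl in place of tert-butyl on an aromatic nitrogen.

Among the compounds with values here, no step between measured compounds is available; since every value so far is a limit, the expected step that the limit leaves unreadable from compound 3 to compound 4 is none beyond the scatter. For compound 4 in this assay the expected efficacy is 4%, within 0% to 15%, most likely reported again as a limit.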

Compound 4, largest response reached (reported as efficacy), in percent of the reference or control that the assay uses: 100%
Compound 4: middle estimate off by 96 percentage points, on the low side, and the stated range ends below it.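

Within the data shown here, the aromatic nitrogen of the five-membered ring is the first place where a single change separates two compounds: in this assay, 3,4-dimethylphenyl in place of tert-butyl gives a number at least 95 percentage points higher from compound 3 to compound 4 (beyond the scatter). This step is only a lower bound, as compound 3 sits at a limit: the limit of < 5% in this assay, at which 3 of the 4 values shown sit. All else in the pair is unchanged, so the whole step belongs to this one substituent.

Going by these compounds, whether the ring or its two methyl groups carry the step stays open; a plain phenyl or a cyclohexyl on this nitrogen would separate the two. On these data alone, whether a carboxylic acid can replace the sulfonic acid of compound 4 also stays open.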